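From thiophen-2-yl to 2-methoxyphenyl: a series at its limit

The source may report more compounds than this note shows. Statements on the series, on what has been measured and on what is new or still open speak of the compounds shown alone.

In a physicochemical assay for pharmacokinetics (on this read-out higher numbers stand for a longer-lived compound and lower numbers for a shorter-lived compound), compound 2 `O=C(NCc1cccs1)N1C(=O)c2ccccc2S1(=O)=O` gives > 166 h as a limit and not a number. Compound 1 `COc1cccc(CNC(=O)N2C(=O)c3ccccc3S2(=O)=O)c1` likewise gives > 166 h as a limit. For the measured compounds named here, the series so far shows only the limit of > 166 h in this assay, at which 2 of the 2 values shown sit, and no readable number.

The change to compound 3 `COc1ccccc1CNC(=O)N1C(=O)c2ccccc2S1(=O)=O` is 2-methoxyphenyl in place of thiophen-2-yl on a saturated chain carbon bound to an amide-type nitrogen and the rest of the structure is shared. Going by the values given here, the one measured step bearing on it is a step that the two limits leave unreadable from compound 1 to compound 2 and it concerns the same place, so no size can be taken from it.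

No step beyond the scatter is expected in this assay because the limit of > 166 h in this assay, at which 2 of the 2 values shown sit, covers compound 1 and compound 2 alike. The estimated step is a step that the limit leaves unreadable from compound 2 to compound 3 with no firm direction behind it. The half-life estimated for compound 3 is 200 h within a range from 100 h to 400 h and a report as a limit is the likely outcome.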

Compound 3, half-life: > 166 h
Compound 3 ended at the assay's limit (the forecaster's own chance of this, stated with the estimate: 85%); the middle value lies beyond the limit too.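

In this assay compound 3 gives > 166 h as a limit and not a number. No step can be read among compound 1, compound 2 and compound 3, which all rest at one limit: the limit of > 166 h in this assay, at which 3 of the 3 values shown sit. As far as these compounds go, whether thiophen-2-yl, 3-methoxyphenyl and 2-methoxyphenyl differ in half-life at all stays open.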